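From Sulfonyl to Carbamate on the Shared Core

The source may report more compounds than this note shows. Statements on the series, on what has been measured and on what is new or still open speak of the compounds shown alone.

Among the measured compounds shown here, compound 3 `Cc1ccc(S(=O)(=O)N2c3ccccc3CC2C(=O)Nc2ccc(C(F)(F)F)cc2)cc1` gives 6680 nM in a functional assay on PC-3 cells (Homo sapiens) for cytotoxicity (a higher number here means a weaker inhibitor of growth, a lower number a stronger inhibitor of growth), the highest number of the three compounds measured so far. Compound 1 `CC(C)(C)OC(=O)N1c2ccccc2CC1C(=O)Nc1ccc([N+](=O)[O-])cc1` gives 2790 nM, and compound 2 `CCCCCCCCC(=O)N1c2ccccc2CC1C(=O)Nc1ccc(C(F)(F)F)cc1` gives 1860 nM. Compound 4 `CC(C)(C)OC(=O)N1c2ccccc2CC1C(=O)Nc1ccc(C(F)(F)F)cc1` is the unmeasured partner of compound 3, and the change is tert-butoxycarbonyl in place of (4-methylphenyl)sulfonyl on a nitrogen on an aromatic ring in a ring. For the measured compounds named here, the only measured step bearing on this position is a 3.6-fold higher number from compound 2 to compound 3 (0.56 log units; beyond the scatter), in which a sulfonyl group displaced a carbonyl-bearing group on that nitrogen and the number rose. Compound 4 brings back a carbonyl-bearing group, the same tert-butoxycarbonyl that compound 1 carries while differing from compound 4 elsewhere. A step down beyond the scatter is therefore expected, estimated as a 2.7-fold lower number from compound 3 to compound 4 (0.43 log units; beyond the scatter). For compound 4 in this assay the expected value is 2500 nM, within 1000 nM to 6000 nM.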

Compound 4, concentration for 50% growth inhibition: 2020 nM
Compound 4: middle estimate off by 1.2-fold (0.09 log units), on the high side; the range from low to high includes it.
By their numbers in this assay, from the lowest: compounds 2, 4 and 1 (each within the scatter of the next); then compound 3.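

In this assay the change from (4-methylphenyl)sulfonyl to tert-butoxycarbonyl gives a 3.3-fold lower number from compound 3 to compound 4 (0.52 log units; beyond the scatter) and so sets compound 3 apart from a second carbonyl-bearing group on this nitrogen. Tert-butoxy in place of octyl on a carbonyl carbon gives a 1.1-fold higher number from compound 2 to compound 4 (0.04 log units; within the scatter) and trifluoromethyl in place of nitro on an aromatic carbon gives a 1.4-fold lower number from compound 1 to compound 4 (0.14 log units; within the scatter) so neither swap separates its pair. Nothing available explains these steps. The compounds shown leave open how a methanesulfonyl group, which lacks the aromatic ring, or an acetyl group would read on this nitrogen.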